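Solubility notes: dimethylphenyl amides on a shared core

This account rests on a few compounds, and the source may have more. Where it says the series, first, only, none or still open, it means among the compounds named here.

Measured so far:
compound 1 `COc1ccc2nc(C)cc(OCC(=O)Nc3cc(C)cc(C)c3)c2c1` — 26000 nM
compound 2 `COc1ccc2nc(C)cc(OCC(=O)Nc3cccc(C)c3)c2c1` — 193000 nM
compound 3 `COc1ccc2nc(C)cc(OCC(=O)Nc3cc(C)ccc3C)c2c1` — 45500 nM

In a physicochemical assay for solubility, in phosphate buffer, measured as kinetic solubility, with a stated time of 1 h, at pH 7.4 (a higher number here means a more soluble compound, a lower number a less soluble compound), compound 3 gives 45500 nM, the second highest of the three numbers. Its nearest neighbour is compound 1 with a 1.8-fold higher number from compound 1 to compound 3 (0.24 log units; within the scatter), so the two sit within the scatter of each other; the furthest is compound 2 with a 4.2-fold lower number from compound 2 to compound 3 (0.63 log units; beyond the scatter).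

Compound 4 `COc1ccc2nc(C)cc(OCC(=O)Nc3c(C)cccc3C)c2c1` has the same atoms as compound 3, joined differently: 2,6-dimethylphenyl in place of 2,5-dimethylphenyl on an amide-type nitrogen. For the measured compounds named here, the measured step that bears most directly on this change is the one from compound 1 to compound 3, which also swaps one dimethylphenyl for another and gave a 1.8-fold higher number from compound 1 to compound 3 (0.24 log units; within the scatter). The two other steps, a 7.4-fold higher number from compound 1 to compound 2 (0.87 log units; beyond the scatter) and a 4.2-fold lower number from compound 2 to compound 3 (0.63 log units; beyond the scatter), remove or add a methyl and are less comparable. On that single relevant step, no change beyond the scatter is expected for compound 4, roughly a 1.1-fold higher number from compound 3 to compound 4 (0.04 log units; within the scatter). The estimate for compound 4 in this assay is 50000 nM, with a range from 18000 nM to 130000 nM.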

Compound 4, solubility: 112000 nM
The estimate for compound 4 lay 2.2-fold (0.35 log units) below the measured number; the range from low to high includes it.
By their numbers in this assay, from the lowest: compounds 1 and 3 (each within the scatter of the next); then compounds 4 and 2 (each within the scatter of the next).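

In this assay, exchanging one dimethylphenyl for another on the amide-type nitrogen is not always a neutral swap: the step is a 2.5-fold higher number from compound 3 to compound 4 (0.39 log units; beyond the scatter), and against the other isomer it is a 4.3-fold higher number from compound 1 to compound 4 (0.63 log units; beyond the scatter), whereas the earlier isomer step, a 1.8-fold higher number from compound 1 to compound 3 (0.24 log units; within the scatter), stayed within the scatter. Compounds 1 and 3 both lie beyond the scatter below the 3-methylphenyl compound, but compound 4 goes against that pattern, with a 1.7-fold lower number from compound 2 to compound 4 (0.24 log units; within the scatter), so a dimethylphenyl group does not by itself go with a lower number in this set. Nothing available here accounts for the difference between the isomers.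

All the aryl groups shown carry only methyl substituents, so it remains open whether chloro, methoxy or ethyl groups in place of the methyl groups of 2,6-dimethylphenyl behave the same. Going by these compounds, the 2-methylphenyl amide, which would show the effect of a single methyl at that place, also remains open.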